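Swapping the dimethylaminoethyl chain of compound 3 for aminocyclohexyl

The compounds below may be only part of what the source reports. "The series", "measured", "known", "first", "only" and "open" are said of these compounds alone.

Of the compounds shown here, three on a shared core have been measured. In a functional assay on K562 cells (Homo sapiens) for cytotoxicity, read by fluorescence, with a stated time of 72 h (on this read-out higher numbers stand for weaker inhibition and lower numbers for stronger inhibition), compound 1 `CC(C)c1n[nH]c2c(NCc3ccc(-c4ccccn4)cc3)nc(NCC(C)(C)O)nc12` gives 29 nM while compound 2 `CC(C)c1n[nH]c2c(NCc3ccc(-c4ccccn4)cc3)nc(NCCN)nc12` gives 63 nM and compound 3 `CC(C)c1n[nH]c2c(NCc3ccc(-c4ccccn4)cc3)nc(NCCN(C)C)nc12` gives 125 nM in the same test. The place of compound 3 is set by two steps: a 4.3-fold higher number from compound 1 to compound 3 (0.63 log units; beyond the scatter) and a 2.0-fold higher number from compound 2 to compound 3 (0.30 log units; within the scatter) so it sits above compound 1 and level with compound 2.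

Compound 4 `CC(C)c1n[nH]c2c(NCc3ccc(-c4ccccn4)cc3)nc(N[C@H]3CC[C@H](N)CC3)nc12` carries 4-aminocyclohexyl in place of 2-(dimethylamino)ethyl on a nitrogen on an aromatic ring is the whole difference.

Going by the values given here, no measured step exchanges a chain for a ring, so the evidence is indirect. The closest guides are a 2.2-fold higher number from compound 1 to compound 2 (0.34 log units; beyond the scatter) and the two steps above, all modest or within the scatter. Compound 4 keeps an amino group, as compound 2 does at 63 nM in this assay and so a modest step towards a lower number is expected. The estimate amounts to a 2.5-fold lower number from compound 3 to compound 4 (0.40 log units; beyond the scatter) and remains uncertain. Compound 4 is expected at 50 nM within a range from 15 nM to 150 nM as a rough estimate.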

Compound 4, half-maximal inhibitory concentration: 593 nM
The estimate for compound 4 lay 12-fold (1.07 log units) below the measured number, outside the stated range (above it).
By their numbers in this assay, from the lowest: compound 1; then compounds 2 and 3 (each within the scatter of the next); then compound 4.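

Replacing the open chains with 4-aminocyclohexyl raised the number in every comparison in this assay: the change gave a 4.7-fold higher number from compound 3 to compound 4 (0.68 log units; beyond the scatter) and a 9.4-fold higher number from compound 2 to compound 4 (0.97 log units; beyond the scatter) and also a 20-fold higher number from compound 1 to compound 4 (1.31 log units; beyond the scatter) in the widest comparison. Compound 4 retains an amino group, as compound 2 does, yet that shared group did not keep the two numbers within the scatter, so this position on the nitrogen on an aromatic ring tolerates less change than the chains alone had shown. The data shown offer nothing that explains this rise.

It remains open whether the ring or the amino group carried on it drives the shift, since a plain cyclohexyl and a 4-hydroxycyclohexyl are not among the compounds shown. The other stereoisomer of 4-aminocyclohexyl also stands outside this set, so the role of the defined stereocentres cannot be judged.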